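A few compounds are considered here, and "the series" means these few. Any claim that something is new, unique, unknown or untested is made for them only; others in the source may bear on it.

In an ADME assay on HepG2 cells (Homo sapiens) for cytotoxicity, with a stated time of 3 days (a higher number here means that more compound is tolerated, a lower number that less compound is tolerated), compound 1, `CC(Sc1nnc(-c2ccncc2)s1)C(=O)Nc1ccc(Cl)cc1`, gives > 50000 nM, which is a limit of the assay and not a number. Compound 2, `CC(CSc1nnc(-c2ccncc2)s1)C(=O)Nc1ccc(Cl)cc1`, gives > 50000 nM, and this too is a limit and not a number. Compound 3, `S=c1[nH]nc(-c2ccncc2)s1`, is the only one of the three with a true number, at 19700 nM. Compound 2 therefore has no exact position on the scale: it stands at the limit of > 50000 nM in this assay, at which 2 of the 3 values shown sit.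

The next compound, compound 4, `CC(CSc1nnc(-c2ccncc2)s1)C(=O)Nc1ccccc1Cl`, has not yet been measured. It has the same atoms as compound 2, joined differently, with 2-chlorophenyl in place of 4-chlorophenyl on an amide-type nitrogen. Within the data shown here, no step between measured compounds is available as a guide, so the expectation rests on the structures and on the limit reached by compound 2. The change leaves the counted features of the group the same, and no step beyond the usual scatter is expected in this assay, in either direction. The expected result, a number no higher from compound 2 to compound 4 (the limit leaves the size open), is therefore small. A report of only a limit is the likeliest outcome. For compound 4 the estimated half-maximal cytotoxic concentration is 50000 nM, with an expected range of 25000 nM to 100000 nM.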

Compound 4, half-maximal cytotoxic concentration: > 50000 nM
Compound 4 was reported as a limit (the forecaster's own chance of this, stated with the estimate: 75%); the middle value lies on the limit itself.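

In this assay compound 2 and compound 4 are both reported only as limits, so no step can be read for 2-chlorophenyl in place of 4-chlorophenyl, and both stand at the same place: the limit of > 50000 nM in this assay, at which 3 of the 4 values shown sit. The compounds shown leave open how much compound either one tolerates beyond that limit, and whether the two chlorophenyl groups differ at all.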